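The source may hold more compounds than are shown below. What is called first, only, known or untested is meant among the compounds shown, and "the series" means these compounds.

Working notes on the series. The measured set holds compound 1 `COc1cc(-c2nn(-c3cccc(NC(=O)c4cccc(C(F)(F)F)c4)c3)cc2-c2ccncc2)ccc1Cl` and compound 2 `O=C(Nc1cccc(-n2cc(-c3ccncc3)c(-c3ccc(Cl)c(O)c3)n2)c1)Nc1cc(C(F)(F)F)cc(C(F)(F)F)c1`. In a functional assay on SR cells (Homo sapiens) for inhibition, read by sulforhodamine B assay, with a stated time of 48 h (on this read-out higher numbers stand for weaker inhibition of growth and lower numbers for stronger inhibition of growth), compound 1 gives 838 nM, and compound 2 gives 922 nM; the two numbers lie within the scatter of each other, so neither stands apart. Compound 3 `COc1cc(-c2nn(-c3cccc(NC(=O)c4ccccc4)c3)cc2-c2ccncc2)ccc1Cl` is not yet measured; it differs from compound 1 by hydrogen in place of trifluoromethyl on an aromatic carbon. Within the data shown here, no measured pair covers this change, so the expectation rests on the structures alone: compound 3 is expected to come out with a somewhat higher number, the estimated step being a 1.9-fold higher number from compound 1 to compound 3 (0.28 log units; within the scatter). For compound 3 the estimate in this assay is 1600 nM, between 500 nM and 5000 nM.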

Compound 3, concentration for 50% growth inhibition: 250 nM
Compound 3: middle estimate off by 6.4-fold (0.81 log units), on the high side; measured number below the stated range.
By their numbers in this assay, from the lowest: compound 3; then compounds 1 and 2 (each within the scatter of the next).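

In this assay, among these compounds, the change from 3-(trifluoromethyl)phenyl to phenyl gives a 3.4-fold lower number from compound 1 to compound 3 (0.53 log units; beyond the scatter) and is the first measured step at this position. Trifluoromethyl on this aromatic carbon is therefore not required for growth inhibition in this pair, and plain hydrogen gives the lower number. Going by these compounds, whether methyl, a fluorine atom, an amine or a carboxylic acid at this place would stay near compound 3 or return toward compound 1 remains open. Nothing measured here accounts for the step.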